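A Hydroxyl Moved, an Inhibition Unchanged

The source may hold more compounds than are shown below. What is called first, only, known or untested is meant among the compounds shown, and "the series" means these compounds.

Compound 1 `Oc1ccc(-c2cc(-c3cccc(O)c3)nc(-c3cccc(O)c3)c2)cc1` and compound 2 `Oc1cccc(-c2cc(-c3ccccc3O)cc(-c3ccccc3O)n2)c1` carry three hydroxyphenyl groups on a shared core. In an assay on isolated protein for inhibition of DNA topoisomerase 1 (Homo sapiens), with a stated time of 30 min, tested at 100 uM (on this read-out lower numbers stand for less inhibition and higher numbers for more inhibition at the one concentration tested (going by the name of the read-out)), compound 1 gives 0%, and in this assay compound 2 gives 0%, so compound 2 stands level with compound 1 within the scatter. Compound 3 `Oc1cccc(-c2cc(-c3ccccc3O)cc(-c3cccc(O)c3)n2)c1` has not been measured; it differs from compound 2 in one place: 3-hydroxyphenyl in place of 2-hydroxyphenyl on an aromatic carbon. With compound 2 at 0% and compound 1 at 0%, no step beyond the scatter is expected in this assay in either direction. Compound 3 is expected to give about 0%, between -8% and 10%, which means an expected step of no change at the digits printed from compound 2 to compound 3 (within the scatter).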

Compound 3, a percentage reported as inhibition, at one concentration (the size of the read-out at that concentration, not a potency): 0%
Estimate against measurement, compound 3: no gap at the digits printed; low and high end bracket the measured number.
By their numbers in this assay, from the lowest: compounds 1, 2 and 3 (each within the scatter of the next).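

In this assay, 3-hydroxyphenyl in place of 2-hydroxyphenyl on the aromatic carbon next to the ring nitrogen gives no change at the digits printed from compound 2 to compound 3 (within the scatter), and 2-hydroxyphenyl in place of 4-hydroxyphenyl gives no change at the digits printed from compound 1 to compound 3 (within the scatter). These single-place steps show that neither exchange among these hydroxyphenyl groups separates the compounds at the one concentration tested. Nothing at hand bears further on this result. The compounds shown leave open whether a different group at this position, such as an aminophenyl group or a carboxylic acid, would give a value beyond the scatter from these.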